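The source may hold more compounds than are shown below. What is called first, only, known or untested is meant among the compounds shown, and "the series" means these compounds.

Compound 1 `c1ccc(-c2cc(-c3cccs3)cc(-c3ccco3)n2)cc1` was tested in a functional assay on A549 cells (Homo sapiens) for antiproliferative activity (on this read-out lower numbers stand for an effect already at smaller amounts and higher numbers for an effect only at larger amounts of compound), where compound 1 gives 118000 nM. Compound 2 `C(=C/c1ccco1)\c1cc(-c2ccco2)cc(-c2cccs2)n1` shares the same core, and in this assay compound 2 gives 118000 nM, so compound 1 stands level with compound 2, the two values lying within the usual scatter. Compound 3 `c1coc(-c2cc(-c3cccs3)cc(-c3ccco3)n2)c1` has not yet been measured; it differs from compound 1 by furan-2-yl in place of phenyl on an aromatic carbon. Among the compounds with values here, with no comparable step measured for compound 1, the expected step is no change at the digits printed from compound 1 to compound 3 (within the scatter), none beyond the scatter. Compound 3 is therefore expected to give 118000 nM, with a likely range from 60000 nM to 240000 nM.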

Compound 3, half-maximal effective concentration: 118000 nM
Estimate against measurement, compound 3: no gap at the digits printed, within the range that was stated.
By their numbers in this assay, from the lowest: compounds 1, 2 and 3 (each within the scatter of the next).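

In this assay, putting furan-2-yl in place of phenyl on the aromatic carbon next to the ring nitrogen gives no change at the digits printed from compound 1 to compound 3 (within the scatter). So at this position, a five-membered ring containing oxygen, a hydrogen-bond acceptor, reads the same as a six-membered ring of carbon only. Still open, from the compounds shown here alone, is whether an amine or a carboxylic acid at this position would shift the value. Going by these compounds, it is also open whether the furan-2-yl and thiophen-2-yl groups elsewhere on the shared core can be exchanged as freely. Nothing available explains why the value stays level.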